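Swapping an aryl amine for a small cyclopropyl ring

The compounds below may be only part of what the source reports. "The series", "measured", "known", "first", "only" and "open" are said of these compounds alone.

Compound 3 `C=CC(=O)Nc1cc(Nc2ncc(Cl)c(Nc3ccc(F)c(Cl)c3)n2)c(OC)cc1N1CCN(C)CC1` is one of three compounds tested in a functional assay on NCI-H3122 cells (Homo sapiens) for inhibition, read by CellTiter-Glo, with a stated time of 72 h; on this read-out higher numbers stand for weaker inhibition of growth and lower numbers for stronger inhibition of growth. Compound 1 `C=CC(=O)Nc1cc(Nc2ncc(Cl)c(Nc3ccccc3S(=O)(=O)C(C)C)n2)c(OC)cc1N1CCN(S(C)(=O)=O)CC1` reaches the limit of that test, giving < 0.3 nM, which is a boundary of the assay rather than a number. Compound 2 `C=CC(=O)Nc1cc(Nc2ncc(Cl)c(Nc3ccccc3S(=O)(=O)C(C)C)n2)c(OC)cc1N1CCN(C(C)C)CC1` likewise sits at the limit, giving < 0.3 nM. Among the compounds with values here, compound 3, in contrast, gives 300 nM, the only actual number among the three. Within the data shown here, the one step between measured compounds, a step that the two limits leave unreadable from compound 1 to compound 2, cannot be read in size, since both ends lie at the limit (the limit of < 0.3 nM in this assay, at which 2 of the 3 values shown sit).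

Compound 4 `C=CC(=O)Nc1cc(Nc2ncc(Cl)c(NC3CC3)n2)c(OC)cc1N1CCN(C)CC1` differs from compound 3 in a single place: cyclopropyl in place of 3-chloro-4-fluorophenyl on a nitrogen on an aromatic ring. Among the measured compounds shown here, no measured step touches this part of the molecule, and the only measured step concerns a different position and is unreadable anyway. The expectation for compound 4 therefore rests on compound 3 alone, with a wide range to reflect that no comparable change has been measured. For compound 4 the expected step is a 2.0-fold higher number from compound 3 to compound 4 (0.30 log units; within the scatter), leaning slightly toward weaker inhibition but with low confidence. The estimate for compound 4 in this assay is 600 nM, between 100 nM and 5000 nM.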

Compound 4, concentration for 50% growth inhibition: 3200 nM
Compound 4: the middle estimate sits 5.3-fold (0.73 log units) below what was measured, and the stated range covers the measured number.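

In this assay, putting cyclopropyl in place of 3-chloro-4-fluorophenyl on the nitrogen on an aromatic ring gives an 11-fold higher number from compound 3 to compound 4 (1.03 log units; beyond the scatter), and this step lies beyond the usual scatter of repeated measurements. Within the data shown here, it is the first readable step, and it shows that the group at this place matters for growth inhibition in these cells: with the rest of the molecule unchanged, the cyclopropyl compound inhibits growth more weakly than the one carrying 3-chloro-4-fluorophenyl. The data show the size and direction of the change, but no measurement shown here explains it.

With only these two groups compared at this place, plain phenyl or cyclohexyl would be needed to separate the effect of removing the chlorine and fluorine from that of replacing the aromatic ring with a non-aromatic one. Going by these compounds, compound 1 and compound 2 differ from compound 3 in more than one place and the step between them cannot be read, so whether the cyclopropyl change would have the same size on their scaffold remains open.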